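From 3-ethylphenyl to 4-chlorophenyl on a sulfonamide nitrogen

The source may hold more compounds than are shown below. What is called first, only, known or untested is meant among the compounds shown, and "the series" means these compounds.

Measured so far in a functional assay on HT-29 cells (Homo sapiens) for antiproliferative activity, read by sulforhodamine B assay, with a stated time of 48 h; on this read-out higher numbers stand for weaker inhibition and lower numbers for stronger inhibition
Compound 1 `Cc1ccc(NS(=O)(=O)c2ccc(N3CCNC3=O)cc2)cc1` gives 480 nM
Compound 2 `O=C1NCCN1c1ccc(S(=O)(=O)Nc2ccc(F)c(F)c2)cc1` gives 350 nM
Compound 3 `CCc1cccc(NS(=O)(=O)c2ccc(N3CCNC3=O)cc2)c1` gives 110 nM

Compound 3 gives the lowest number of the three. The measured gaps to it are a 4.4-fold lower number from compound 1 to compound 3 (0.64 log units; beyond the scatter) and a 3.2-fold lower number from compound 2 to compound 3 (0.50 log units; beyond the scatter) and both are modest. The remaining comparison is a 1.4-fold lower number from compound 1 to compound 2 (0.14 log units; within the scatter) and it separates the two other groups by no meaningful margin.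

Compound 4 `O=C1NCCN1c1ccc(S(=O)(=O)Nc2ccc(Cl)cc2)cc1` puts 4-chlorophenyl in place of 3-ethylphenyl on a sulfonamide nitrogen and leaves the rest of the molecule unchanged. Among the measured compounds shown here, no measured compound carries 4-chlorophenyl, so the comparison rests on only three neighbours. Both measured compounds without 3-ethylphenyl gave higher numbers, compound 1 at 480 nM and compound 2 at 350 nM on the same read-out. A modest move toward a higher number is therefore expected in this assay and the estimated change is a 3.6-fold higher number from compound 3 to compound 4 (0.56 log units; beyond the scatter) for this swap. Compound 4 is estimated at 400 nM with 150 nM to 1100 nM as the expected range.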

Compound 4, half-maximal inhibitory concentration: 220 nM
Compound 4: the middle estimate sits 1.8-fold (0.26 log units) above what was measured; measured number inside the range.
By their numbers in this assay, from the lowest: compounds 3, 4, 2 and 1 (each within the scatter of the next, the first and the last beyond it).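

In this assay, 4-chlorophenyl on a sulfonamide nitrogen stays within the scatter of both 3-ethylphenyl (a 2.0-fold higher number from compound 3 to compound 4 (0.30 log units; within the scatter)) and 3,4-difluorophenyl (a 1.6-fold lower number from compound 2 to compound 4 (0.20 log units; within the scatter)), so 3-ethylphenyl no longer stands apart from every other group at this place. Chloro in place of methyl on an aromatic carbon gives a modest step beyond the scatter (a 2.2-fold lower number from compound 1 to compound 4 (0.34 log units; beyond the scatter)), which shows that this single exchange on the ring can register in the assay. Nothing available explains these differences.

The compounds shown leave open whether 3-chlorophenyl or 4-ethylphenyl would read like their counterparts here, which would help separate the identity of the group from where it sits on the ring. They also leave open how an amine, a carboxylic acid or a propyl chain on that ring would read.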